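A ring-bearing amine replaces the dimethylaminopropyl chain

This account rests on a few compounds, and the source may have more. Where it says the series, first, only, none or still open, it means among the compounds named here.

In a functional assay on HCT-116 cells (Homo sapiens) for cytotoxicity, read by MTT assay, with a stated time of 72 h (a lower number here means a stronger inhibitor, a higher number a weaker inhibitor), compound 1 (`CS(=O)(=O)Oc1c(C(=O)NCc2ccc(F)cc2)nc(Br)c2cccnc12`) gives > 20000 nM as a limit and not a number. Compound 2 (`Nc1ccc(Nc2c(C(=O)NCc3ccc(F)cc3)nc(Br)c3cccnc23)cc1`) gives 7000 nM in the same test. Compound 3 (`CN(C)CCCNc1c(C(=O)NCc2ccc(F)cc2)nc(Br)c2cccnc12`) gives > 10000 nM as a limit too, so it has no exact place on the scale. Compound 4 (`N[C@H]1CC[C@H](Nc2c(C(=O)NCc3ccc(F)cc3)nc(Br)c3cccnc23)CC1`) departs from compound 3 by 4-aminocyclohexyl in place of 3-(dimethylamino)propyl on a nitrogen on an aromatic ring with 4-aminocyclohexyl in place of 3-(dimethylamino)propyl on a nitrogen on an aromatic ring.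

Among the measured compounds shown here, three measured steps bear on this change. The step to the (4-aminophenyl)amino group gave an at least 2.8-fold lower number from compound 1 to compound 2 (0.45 log units; beyond the scatter) while the step to the (3-(dimethylamino)propyl)amino group gave a step that the two limits leave unreadable from compound 1 to compound 3 and the swap between these two groups gave an at least 1.4-fold higher number from compound 2 to compound 3 (0.15 log units; that floor lies within the scatter) in turn. Compound 4 carries an amino group on a ring, as compound 2 does at 7000 nM in this comparison. A modest move towards a lower number is therefore expected, estimated as an at least 1.6-fold lower number from compound 3 to compound 4 (0.22 log units; that floor lies within the scatter) and possibly no larger than the scatter. For compound 4 the estimated value is 6000 nM with an expected range from 1500 nM to 20000 nM in this assay.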

Compound 4, half-maximal inhibitory concentration: 4000 nM
Estimate against measurement, compound 4: 1.5-fold (0.18 log units) above; the range from low to high includes it.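

In this assay, the 4-aminocyclohexyl group on this nitrogen gives a number where the 3-(dimethylamino)propyl chain gave only a limit, with an at least 2.5-fold lower number from compound 3 to compound 4 (0.39 log units; beyond the scatter), a size that is a floor only. Set against the 4-aminophenyl group, the saturated ring gives a 1.8-fold lower number from compound 2 to compound 4 (0.24 log units; within the scatter), so an aromatic ring is not required on this nitrogen to reach this level of activity. The (4-aminocyclohexyl)amino group also stands clear of the (methylsulfonyl)oxy group, with an at least 5.0-fold lower number from compound 1 to compound 4 (0.69 log units; beyond the scatter), though that size too is a floor, set by the limit of compound 1: the limit of > 20000 nM in this assay, at which 1 of the 4 values shown sits.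

The compounds shown leave open whether the amino group or the ring itself matters, which a plain cyclohexyl group or a 4-hydroxycyclohexyl group would separate. They also leave open how the other stereoisomer of the 4-aminocyclohexyl group would read.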